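The compounds below may be only part of what the source reports. "The series", "measured", "known", "first", "only" and "open" are said of these compounds alone.

Measured compounds:
- compound 1 `CC(=O)N[C@H]1[C@H]([C@@H](O)[C@H](O)CNC(=O)c2ccc(Cl)cc2)O[C@@](OCc2ccccc2)(C(=O)O)C[C@@H]1O` — 17000 nM
- compound 2 `O=C(CCl)N[C@H]1[C@H]([C@@H](O)[C@H](O)CNC(=O)c2ccc(Cl)cc2)O[C@@](OCc2cccc(F)c2F)(C(=O)O)C[C@@H]1O` — 2100 nM

The read-out throughout is an in vitro assay on cells for binding affinity to myelin-associated glycoprotein (Mus musculus), read by surface plasmon resonance; a higher number here means weaker binding, a lower number tighter binding. Compound 2 holds the lower of the two numbers on record; compound 1, which differs from it at more than one site, gives a higher value that lies beyond the scatter, so no single change can be credited with the gap between them.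

Compound 3 `COCC(=O)N[C@H]1[C@H]([C@@H](O)[C@H](O)CNC(=O)c2ccc(Cl)cc2)O[C@@](OCc2cccc(F)c2F)(C(=O)O)C[C@@H]1O` is not yet measured. It keeps the core of compound 2 and carries one change: methoxy in place of chloro on a saturated chain carbon bound to a carbonyl carbon. No measured pair in the series isolates this kind of exchange, so the size of the step rests on judgement rather than on a shown step. The halogen on the chain carbon bound to the carbonyl is traded for an oxygen-bearing substituent of similar size; the expectation is a small shift, likely toward a somewhat higher number, but not clearly beyond the scatter. The step from compound 2 to compound 3 is estimated as a 1.7-fold higher number from compound 2 to compound 3 (0.22 log units; within the scatter). In this assay compound 3 is expected to give about 3500 nM, within a range of 1200 nM to 10000 nM.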

Compound 3, dissociation constant: 2300 nM
The estimate for compound 3 lay 1.5-fold (0.18 log units) above the measured number; measured number inside the range.
By their numbers in this assay, from the lowest: compounds 2 and 3 (each within the scatter of the next); then compound 1.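

In this assay, among the compounds shown here, the first single-site step, methoxy in place of chloro on a saturated chain carbon bound to a carbonyl carbon, reads as a 1.1-fold higher number from compound 2 to compound 3 (0.04 log units; within the scatter), so the two compounds cannot be told apart in this read-out. At this position, then, one chlorine can give way to methoxy, with its two heavy atoms and one hydrogen-bond acceptor, without a step beyond the scatter, though this rests on a single pair and supports no general rule for the position. Steps involving compound 1 still cannot be read, as it differs from both other compounds at more than one site, and nothing on record offers a reason for the result.

The compounds shown leave open whether the same position would stay within the scatter with a charged or larger group, such as an amine, a carboxylic acid or a longer chain in place of methoxy. They also leave open how much of the gap to compound 1 belongs to this position and how much to the other site that differs.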